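The source may hold more compounds than are shown below. What is called first, only, known or untested is meant among the compounds shown, and "the series" means these compounds.

Compound 1 `CCOC(=O)c1cn(Cc2c(F)cccc2F)c2nc(-c3ccc(NC(=O)NCc4cn(CCOCCOCCOCCN=[N+]=[N-])nn4)cc3)c(CN(C)Cc3ccccc3)n2c1=O` — in a functional assay on CHO cells for antagonist activity at Gonadotropin-releasing hormone receptor (Homo sapiens), read by a luciferase reporter, with a stated time of 30 min (a higher number here means a weaker inhibitor, a lower number a stronger inhibitor), compound 1 gives 3020 nM.
Compound 2 `CCNC(=O)Nc1ccc(-c2nc3n(Cc4c(F)cccc4F)cc(C(=O)OCC)c(=O)n3c2CN(CC(=O)NCc2cn(CCN=[N+]=[N-])nn2)Cc2ccccc2)cc1` — in this assay compound 2 gives 724 nM.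
Compound 3 `CCOC(=O)c1cn(Cc2c(F)cccc2F)c2nc(-c3ccc(NC(=O)NCc4cn(CCN=[N+]=[N-])nn4)cc3)c(CN(C)Cc3ccccc3)n2c1=O` — in this assay compound 3 gives 2570 nM.

Compound 2 shows the lowest number of the three, and its gaps to compound 3 and compound 1 both lie beyond the usual scatter. Compounds 1 and 3 share one core, and compound 1 carries 2-(2-(2-azidoethoxy)ethoxy)ethoxy in place of azido on a saturated chain carbon, two bonds along the chain from an aromatic nitrogen; this change gave a 1.2-fold higher number from compound 3 to compound 1 (0.07 log units; within the scatter), a step that stays within the scatter. The difference between the core of compound 2 and the core of compound 3 is not broken down here.

Compound 4 `CCNC(=O)Nc1ccc(-c2nc3n(Cc4c(F)cccc4F)cc(C(=O)OCC)c(=O)n3c2CN(CC(=O)NCc2cn(CCOCCOCCOCCN=[N+]=[N-])nn2)Cc2ccccc2)cc1` is not yet measured. Compared with compound 2 it carries 2-(2-(2-azidoethoxy)ethoxy)ethoxy in place of azido on a saturated chain carbon, two bonds along the chain from an aromatic nitrogen, which is the same change, at the same place, that was made from compound 3 to compound 1. Since that earlier change moved the number only within the scatter, compound 4 is expected to land near compound 2, with an estimated step of a 1.2-fold higher number from compound 2 to compound 4 (0.07 log units; within the scatter) in this assay. The estimate for compound 4 is therefore 850 nM, expected to fall between 400 nM and 1800 nM.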

Compound 4, half-maximal inhibitory concentration: 724 nM
Beside the measured number, compound 4's estimate is 1.2-fold (0.07 log units) above it, within the range that was stated.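

In this assay, putting 2-(2-(2-azidoethoxy)ethoxy)ethoxy in place of azido gave no change at the digits printed from compound 2 to compound 4 (within the scatter), and the step on the second core matches the one on the first: the same change on two cores in this assay, a 1.2-fold higher number (0.07 log units; within the scatter) from compound 3 to compound 1 and no change at the digits printed (within the scatter) from compound 2 to compound 4, 1.2-fold (0.07 log units) apart, within the scatter of two such steps. Across these two matched pairs the change therefore carries from one core to the other, and on both cores the number stays within the scatter even though the new group is much larger than azido by its count of heavy atoms. Among the compounds shown here, this rests on only two cores and one assay, so it does not show that the change would be equally silent on any other core, and it says nothing about why the two steps agree or about what separates the two cores themselves.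

On these data alone, whether a longer chain, or an amine or a carboxylic acid in place of azido on the same saturated chain carbon, would also leave the number unmoved remains open. So does whether the agreement would hold on a third core.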